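Notes on the step from compound 1 to compound 3

The compounds below may be only part of what the source reports. "The series", "measured", "known", "first", "only" and "open" are said of these compounds alone.

- compound 1 `CCCCn1cc(C(=O)O)c(=O)c2cc(F)c(N3CCC(C(N)=O)CC3)cc21`: > 100000 nM (a limit)
- compound 2 `CCCCn1cc(C(=O)NCc2ccco2)c(=O)c2cc(F)c(N3CCC(C(N)=O)CC3)cc21`: 41400 nM
- compound 3 `CCCCn1cc(C(=O)O)c(=O)c2cc(F)c(N(C)Cc3ccccc3)cc21`: not yet measured

In an ADME assay on J774.1 cells (Mus musculus) for cytotoxicity, read by resazurin assay, with a stated time of 48 h (a higher number here means a weaker inhibitor, a lower number a stronger inhibitor), compound 1 gives > 100000 nM, which is a limit of the assay and not a number. Compound 1 therefore stands at the limit of > 100000 nM in this assay, at which 1 of the 2 values shown sits.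

Compound 3 keeps the hydroxy on the carbonyl carbon and carries benzyl(methyl)amino in place of 4-carbamoylpiperidin-1-yl on an aromatic carbon, ortho to a fluoro group: benzyl(methyl)amino in place of 4-carbamoylpiperidin-1-yl on an aromatic carbon.

Going by the values given here, the only measured step, an at least 2.4-fold lower number from compound 1 to compound 2 (0.38 log units; beyond the scatter), changes a different place, so it bears on this one only loosely. In that step compound 2 reaches 41400 nM. On the strength of that step, a modest move to a lower number is expected in this assay, though a step within the scatter remains possible. The expected step is an at least 1.6-fold lower number from compound 1 to compound 3 (0.22 log units; that floor lies within the scatter). For compound 3 the estimate is 60000 nM, with an expected range of 20000 nM to 100000 nM.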

Compound 3, half-maximal inhibitory concentration: 43200 nM
For compound 3 the middle estimate is 1.4-fold (0.14 log units) above the measured one; the range from low to high includes it.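

In this assay, the position ortho to the fluoro group also responds with the hydroxy on the carbonyl carbon left in place, whereas the earlier pair showed a change only at the carbonyl carbon. Benzyl(methyl)amino in place of 4-carbamoylpiperidin-1-yl gives an at least 2.3-fold lower number from compound 1 to compound 3 (0.36 log units; beyond the scatter), so a lower number in this assay does not depend on replacing that hydroxy. The true size of this step stays unknown because the reference for it is a limit and not a number: the limit of > 100000 nM in this assay, at which 1 of the 3 values shown sits.

Still open, as far as these compounds go, is whether the benzyl ring or the methyl on the nitrogen accounts for the step, which a simple dimethylamino or a morpholin-4-yl group at this position could help to separate. Also open, from the compounds shown here alone, is how a shorter or longer chain in place of the butyl group would behave at the same position.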